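This account rests on a few compounds, and the source may have more. Where it says the series, first, only, none or still open, it means among the compounds named here.

In a functional assay (trachea) with Cavia porcellus as the target (on this read-out lower numbers stand for stronger inhibition and higher numbers for weaker inhibition), compound 2 (`O=C(c1cccs1)n1nc(-c2cccnc2)c2ccccc2c1=O`) stands at 12300 nM and holds the higher of the two numbers, with compound 1 (`O=c1c2ccccc2c(-c2cccnc2)nn1CC1CCCCC1`) at 209 nM on the lower side. Compound 3 (`O=c1c2ccccc2c(-c2cccnc2)nn1CCO`) differs from compound 2 on that same aromatic nitrogen (2-hydroxyethyl in place of (thiophen-2-yl)carbonyl on an aromatic nitrogen). Among the measured compounds shown here, the only measured step at this place is large and beyond the scatter (a 59-fold higher number from compound 1 to compound 2 (1.77 log units; beyond the scatter)). It suggests that replacing (thiophen-2-yl)carbonyl with an alkyl-linked group could recover part of that loss, though 2-hydroxyethyl has not been tested. A lower number is therefore expected, with an estimated step (a 6.2-fold lower number from compound 2 to compound 3 (0.79 log units; beyond the scatter)). The estimate for compound 3 is 2000 nM with an expected range (350 nM to 11000 nM).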

Compound 3, half-maximal inhibitory concentration: 4570 nM
Estimate against measurement, compound 3: 2.3-fold (0.36 log units) below; the range from low to high includes it.
By their numbers in this assay, from the lowest: compound 1; then compound 3; then compound 2.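

In this assay, the change to 2-hydroxyethyl gives only a 2.7-fold lower number from compound 2 to compound 3 (0.43 log units; beyond the scatter) and recovers little of the ground lost with (thiophen-2-yl)carbonyl. Keeping the saturated chain carbon on the aromatic nitrogen is therefore not enough, since hydroxymethyl in place of cyclohexyl gives a 22-fold higher number from compound 1 to compound 3 (1.34 log units; beyond the scatter) and the group beyond that carbon carries a large step. Nothing available explains this order. On these data alone, whether a chain ending in an amine or a carboxylic acid, or a longer chain bearing cyclohexyl, would come closer to compound 1 remains open.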